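Swapping methoxy for hydroxy in compound 1

The source may report more compounds than this note shows. Statements on the series, on what has been measured and on what is new or still open speak of the compounds shown alone.

Compound 1 `COc1ccc(C=C(C(=O)/C=C/c2cccc(OC)c2OC)C(=O)/C=C/c2cccc(OC)c2OC)cc1OC`: 560 nM
Compound 2 `COc1cc(OC)c(C=C(C(=O)/C=C/c2cccc(OC)c2OC)C(=O)/C=C/c2cccc(OC)c2OC)c(OC)c1`: 720 nM
Compound 3 `COc1cccc(/C=C/C(=O)C(=Cc2ccc(O)c(F)c2)C(=O)/C=C/c2cccc(OC)c2OC)c1OC`: 300 nM

In a functional assay on MCF7 cells (Homo sapiens) for antiproliferative activity, read by sulforhodamine B assay, with a stated time of 48 h (on this read-out lower numbers stand for stronger inhibition and higher numbers for weaker inhibition), compound 1 gives 560 nM, a number within the scatter of both other compounds. Only the two others are told apart, with a 2.4-fold lower number from compound 2 to compound 3 (0.38 log units; beyond the scatter).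

Compound 4 `COc1ccc(C=C(C(=O)/C=C/c2cccc(OC)c2OC)C(=O)/C=C/c2cccc(OC)c2OC)cc1O` has not been measured. It differs from compound 1 in one place: hydrogen in place of methyl on an oxygen on an aromatic ring. In words, hydrogen sits in place of methyl on an oxygen on an aromatic ring, turning 3,4-dimethoxyphenyl into 3-hydroxy-4-methoxyphenyl.

Within the data shown here, no measured step makes exactly this change. The nearest guide is compound 3 at 300 nM, whose 3-fluoro-4-hydroxyphenyl group also holds a hydroxy. That swap gave a 1.9-fold lower number from compound 1 to compound 3 (0.27 log units; within the scatter). The other swap at this place gave a 1.3-fold higher number from compound 1 to compound 2 (0.11 log units; within the scatter). Both are small, so only a small move toward lower numbers seems likely.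

The expected step is a 1.4-fold lower number from compound 1 to compound 4 (0.15 log units; within the scatter). Compound 4 is expected at about 400 nM, with an estimated range from 160 nM to 1000 nM.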

Compound 4, half-maximal inhibitory concentration: 310 nM
For compound 4 the middle estimate is 1.3-fold (0.11 log units) above the measured one, within the range that was stated.
By their numbers in this assay, from the lowest: compounds 3, 4, 1 and 2 (each within the scatter of the next, the first and the last beyond it).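

Taking the methyl off one oxygen of the 3,4-dimethoxyphenyl group gives a 1.8-fold lower number from compound 1 to compound 4 (0.26 log units; within the scatter) in this assay, so a free hydroxy is accepted at this place without a loss that can be read. Compound 4 also cannot be told apart from the fluorinated phenol, with a 1.0-fold higher number from compound 3 to compound 4 (0.01 log units; within the scatter), which shows that a hydroxy can sit on this ring with or without fluorine and with a methoxy present. Only against the 2,4,6-trimethoxyphenyl group does the change reach beyond the scatter, with a 2.3-fold lower number from compound 2 to compound 4 (0.37 log units; beyond the scatter), whereas compound 1 stays within it.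

Nothing given here explains these numbers. Going by these compounds, whether an amine, a carboxylic acid or a longer chain such as ethoxy on this oxygen would keep or change the number remains open.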